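The source may hold more compounds than are shown below. What is called first, only, known or untested is meant among the compounds shown, and "the series" means these compounds.

Series notes. Among the compounds with values here, compound 1 `CCCS(=O)(=O)Nc1cccc2c1CCC2c1ncc[nH]1` is the first measured member. In a functional assay on CHO cells for agonist activity at Alpha-1B adrenergic receptor (Homo sapiens), read by FLIPR and calcium flux (on this read-out lower numbers stand for an effect already at smaller amounts and higher numbers for an effect only at larger amounts of compound), compound 1 gives only a limit, > 10000 nM, and not a number. Compound 2 `CCS(=O)(=O)Nc1cccc(Cc2c[nH]cn2)c1` is the second measured member. In this assay compound 2 likewise returns a limit, > 10000 nM, rather than a number. So compound 1 stands at the limit of what has been measured, and no step between measured compounds can be read off, because the limit of > 10000 nM in this assay, at which 2 of the 2 values shown sit, is where everything so far sits.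

Compound 3 `CS(=O)(=O)Nc1cccc2c1CCC2c1ncc[nH]1` is the unmeasured member: hydrogen in place of ethyl on a saturated chain carbon bound to a sulfonyl sulfur. Propylsulfonyl becomes methylsulfonyl and (propylsulfonyl)amino becomes methanesulfonamido. With both measured values sitting at the limit, nothing seen so far marks a direction for this change, and the expectation is that compound 3 stays at or near the limit. The step from compound 1 to compound 3 in this assay is expected to be a step that the limit leaves unreadable from compound 1 to compound 3, no shift beyond the scatter. For compound 3 the estimate in this assay is 20000 nM, with a range from 5000 nM to 100000 nM.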

Compound 3, half-maximal effective concentration: > 10000 nM
Compound 3 gave a limit, no number (the forecaster's own chance of this, stated with the estimate: 85%); the middle value lies beyond the limit too.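

No step can be read between compound 1 and compound 3 in this assay, because both compounds sit at a limit and neither gives a number: the limit of > 10000 nM in this assay, at which 3 of the 3 values shown sit.

The compounds shown leave open whether any member of this series gives a number in this assay, and what effect, if any, the change from propylsulfonyl to methylsulfonyl has there.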